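Swapping an ethyl for a cyclopropyl on a receptor ligand

The source may report more compounds than this note shows. Statements on the series, on what has been measured and on what is new or still open speak of the compounds shown alone.

Measured compounds:
compound 1, `CCc1nc2c(-c3ccc(C(F)(F)F)cc3Cl)nccc2n1C(CC)CC`, 5.4 nM
compound 2, `CCc1nc2c(-c3ccc(Cl)cc3C)nccc2n1C(CC)C1CC1`, 14 nM

Both compounds were tested in an assay for binding affinity to Corticotropin releasing factor receptor (Rattus norvegicus); on this read-out higher numbers stand for weaker inhibition and lower numbers for stronger inhibition. Of the two numbers, compound 1 has the lower one, and the gap to compound 2 lies beyond the usual scatter of repeated measurements. Compound 2 differs from compound 1 in two places at once, in the side chain and in the aromatic ring, so the two values alone do not separate the two changes.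

The unmeasured compound 3, `CCc1nc2c(-c3ccc(C(F)(F)F)cc3Cl)nccc2n1C(CC)C1CC1`, keeps the aromatic ring of compound 1 and alters only the side chain: cyclopropyl in place of ethyl on a saturated chain carbon bound to an aromatic nitrogen and a saturated chain carbon. Read one bond further out, pentan-3-yl becomes 1-cyclopropylpropyl, the same side chain that compound 2 carries.

For the measured compounds named here, no measured pair isolates this exchange, so the expectation rests on the small size of the change: in this assay the step is expected to stay within the usual scatter. The estimated step from compound 1 to compound 3 is a 1.3-fold higher number from compound 1 to compound 3 (0.11 log units; within the scatter). Compound 3 is therefore expected to give about 7 nM, within a range from 2.5 nM to 20 nM.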

Compound 3, inhibition constant: 2.9 nM
Beside the measured number, compound 3's estimate is 2.4-fold (0.38 log units) above it; the measured number falls inside the stated range.
By their numbers in this assay, from the lowest: compounds 3 and 1 (each within the scatter of the next); then compound 2.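

In this assay, the exchange of ethyl for cyclopropyl on this saturated chain carbon gives a 1.9-fold lower number from compound 1 to compound 3 (0.27 log units; within the scatter) and so shows that this position accepts a three-membered ring with no change that can be told apart from the usual scatter. The same exchange also gives a pair that shares the 1-cyclopropylpropyl side chain and differs only in the aromatic ring: compound 3 gives 2.9 nM and compound 2 gives 14 nM in this assay with the two ring patterns side by side. No measurement shown here explains why the cyclopropyl group is accepted at this position.

The compounds shown leave open how far this tolerance reaches, since a larger ring such as cyclobutyl, a longer chain such as butyl, or a chain with an ether oxygen such as methoxymethyl could behave quite differently in the same place. It also remains open whether the ethyl to cyclopropyl exchange would give a similar result on the aromatic ring of compound 2, whose pentan-3-yl partner does not appear among these compounds.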